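Chloro-to-methoxy swap on a pyrazole amide series

The source may report more compounds than this note shows. Statements on the series, on what has been measured and on what is new or still open speak of the compounds shown alone.

Measured compounds:
compound 1 `O=C(Nc1cc(-c2ccccc2)[nH]n1)c1cccnc1Cl`, 7340 nM
compound 2 `COc1ncccc1C(=O)Nc1cc(-c2ccccc2)[nH]n1`, 9940 nM
compound 3 `Cc1ccc(-c2cc(NC(=O)c3ccc(Cl)nc3)n[nH]2)cc1`, 6880 nM

In a functional assay on A-375 cells (Homo sapiens) for antiproliferative activity, read by MTT assay, with a stated time of 48 h (on this read-out higher numbers stand for weaker inhibition and lower numbers for stronger inhibition), compound 1 gives 7340 nM. Compound 2, which carries methoxy in place of chloro on an aromatic carbon, gives 9940 nM in this assay, so the step of a 1.4-fold higher number from compound 1 to compound 2 (0.13 log units; within the scatter) is small. Compound 3 gives 6880 nM in this assay; its difference from compound 1 is not broken down here, and the two values lie close together.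

Compound 4 `COc1ccc(C(=O)Nc2cc(-c3ccc(C)cc3)[nH]n2)cn1` has not yet been measured. It differs from compound 3 by methoxy in place of chloro on an aromatic carbon. Among the compounds with values here, this is the same kind of change as the one from compound 1 to compound 2, but the place is not identical: there the methoxy stands ortho to a large group, here it stands para to a large group. Because a 1.4-fold higher number from compound 1 to compound 2 (0.13 log units; within the scatter) stayed within the scatter, a similarly small step is expected for compound 4, a 1.4-fold higher number from compound 3 to compound 4 (0.14 log units; within the scatter). The estimate for compound 4 in this assay is therefore 9500 nM, likely between 4000 nM and 25000 nM.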

Compound 4, half-maximal inhibitory concentration: 8420 nM
Compound 4: the middle estimate sits 1.1-fold (0.05 log units) above what was measured; measured number inside the range.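

In this assay, putting methoxy in place of chloro on the core of compound 3 gives a 1.2-fold higher number from compound 3 to compound 4 (0.09 log units; within the scatter), so the swap leaves the number about where it was. The same swap on the core of compound 1 gave a step of similar size, and the two steps agree: the same change on two cores in this assay, a 1.4-fold higher number (0.13 log units; within the scatter) from compound 1 to compound 2 and a 1.2-fold higher number (0.09 log units; within the scatter) from compound 3 to compound 4, 1.1-fold (0.04 log units) apart, within the scatter of two such steps. This shows that, in these two pairs, the change carries from one core to the other without a visible shift in the read-out, but it does not show that either group is better, since both steps lie within the scatter, and two pairs cannot establish a rule for the whole series.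

The compounds shown leave open how an amine, a carboxylic acid or a longer chain such as ethoxy would read on this same aromatic carbon, and whether any of them would give a step beyond the scatter. They also leave open whether the swap stays this small on other cores.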